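This account rests on a few compounds, and the source may have more. Where it says the series, first, only, none or still open, it means among the compounds named here.

Measured compounds: compound 1 `CC(C)C[C@H](O)[C@H](O)[C@@H](N)CC1CCCCC1` with 1.86; compound 2 `CC(C)C[C@H](O)[C@H](O)[C@H](CC1CCCCC1)NC(=O)OC(C)(C)C` with 3.98; compound 3 `CC(C)C[C@H](O)[C@H](O)[C@H](CC1CCCCC1)NC(=O)C[C@@H](NC(=O)OC(C)(C)C)C(=O)O` with 2.06, all in a physicochemical assay for lipophilicity; on this read-out higher numbers stand for higher lipophilicity and lower numbers for lower lipophilicity.

Compound 2 stands highest of the three in this assay: its nearest neighbour is compound 3, and the furthest is compound 1, both lying beyond the scatter below it. The step from compound 2 to compound 4 `CC(C)C[C@H](O)[C@H](O)[C@H](CC1CCCCC1)NC(=O)/C=C/c1ccccc1` is 2-phenylethenyl in place of tert-butoxy on a carbonyl carbon. Among the measured compounds shown here, the only measured step, a number 2.12 log units higher from compound 1 to compound 2 (beyond the scatter), concerns a different change at the amine nitrogen, so no measured step bears directly on this exchange. On the structures alone, the step of a number 0.42 log units higher from compound 2 to compound 4 (beyond the scatter) is expected to be modest and upward. Compound 4 is therefore estimated at 4.4, within a range from 3.8 to 5.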

Compound 4, partition coefficient: 3.61
Beside the measured number, compound 4's estimate is 0.79 log units above it; the whole stated range lies above it.
By their numbers in this assay, from the lowest: compounds 1 and 3 (each within the scatter of the next); then compound 4; then compound 2.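

In this assay the exchange on a carbonyl carbon whose other neighbours are amide-type nitrogen gives a number 0.37 log units lower from compound 2 to compound 4 (beyond the scatter) and so shows that 2-phenylethenyl, though it has more heavy atoms than tert-butoxy, does not raise the number at this position. The earlier step of a number 2.12 log units higher from compound 1 to compound 2 (beyond the scatter) compared a substituent with hydrogen and said nothing about exchanging one carbonyl substituent for another. Nothing available explains the direction of the new step.

Open, from the compounds shown here alone, is whether a saturated 2-phenylethyl chain, or a phenyl ring carrying an amine or a carboxylic acid, would move the number the same way on this carbonyl carbon.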